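Trimethoxyphenyl for Fluorophenyl on the Ketone: Expected Effect

The source may report more compounds than this note shows. Statements on the series, on what has been measured and on what is new or still open speak of the compounds shown alone.

Measured so far in a functional assay on MCF7 cells (Homo sapiens) for cytotoxicity, read by MTT assay, with a stated time of 48 h; on this read-out lower numbers stand for stronger inhibition and higher numbers for weaker inhibition:
- compound 1 `COc1cc(C(=O)C2Sc3nnc(-c4cc(OC)c(OC)c(OC)c4)n3NC2c2ccco2)cc(OC)c1OC`: > 100000 nM
- compound 2 `COc1cc(-c2nnc3n2NC(c2ccco2)C(C(=O)c2ccc(F)cc2)S3)cc(OC)c1OC`: > 100000 nM
- compound 3 `COc1cc(-c2nnc3n2NC(c2cccs2)C(C(=O)c2ccc(F)cc2)S3)cc(OC)c1OC`: 43700 nM

The result for compound 1 in this assay is a limit of the assay and not a number. The result for compound 2 is likewise a limit and not a number. For the measured compounds named here, compound 3 is the only member with a read number; it stands apart from compound 2 by thiophen-2-yl in place of furan-2-yl on a saturated ring carbon, and the step is an at least 2.2-fold lower number from compound 2 to compound 3 (0.35 log units; beyond the scatter).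

The change from compound 2 to compound 1 is 3,4,5-trimethoxyphenyl in place of 4-fluorophenyl on a carbonyl carbon. Its step is a step that the two limits leave unreadable from compound 2 to compound 1, which rests on the limit of > 100000 nM in this assay, at which 2 of the 3 values shown sit, and so cannot be sized.

Compound 4 `COc1cc(C(=O)C2Sc3nnc(-c4cc(OC)c(OC)c(OC)c4)n3NC2c2cccs2)cc(OC)c1OC` carries the same change on the core of compound 3: 3,4,5-trimethoxyphenyl in place of 4-fluorophenyl on a carbonyl carbon. The place lines of the two changes read the same word for word, so this is the same change, now made on the thiophen-2-yl series rather than the furan-2-yl one. With only an unreadable step from compound 2 to compound 1 to go on, the size of the step from compound 3 to compound 4 is estimated as a 1.8-fold higher number from compound 3 to compound 4 (0.26 log units; within the scatter), with a wide spread, and a fair chance that only a limit is reported. Compound 4 is expected to give about 80000 nM in this assay, between 30000 nM and 200000 nM.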

Compound 4, half-maximal inhibitory concentration: 71000 nM
Compound 4: middle estimate off by 1.1-fold (0.05 log units), on the high side; the range from low to high includes it.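

In this assay, 3,4,5-trimethoxyphenyl in place of 4-fluorophenyl on a carbonyl carbon gives a 1.6-fold higher number from compound 3 to compound 4 (0.21 log units; within the scatter), so on the thiophen-2-yl series this change shows no effect that can be told from the usual scatter. The same change on the furan-2-yl series, the step from compound 2 to compound 1, cannot be read, so the series shows neither that the change carries from one core to the other nor that it fails to: the limit of > 100000 nM in this assay, at which 2 of the 4 values shown sit. The other change, thiophen-2-yl in place of furan-2-yl on a saturated ring carbon, gives an at least 1.4-fold lower number from compound 1 to compound 4 (0.14 log units; that floor lies within the scatter) on the core of compound 1, and both of its steps point the same way, although each is only a floor and their sizes cannot be compared: the same change on two cores in this assay, an at least 2.2-fold lower number (0.35 log units; beyond the scatter) from compound 2 to compound 3 and an at least 1.4-fold lower number (0.14 log units; that floor lies within the scatter) from compound 1 to compound 4; the limit leaves it open whether they differ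

The compounds shown leave open whether any group on the carbonyl carbon separates from the scatter, for example a phenyl carrying an amine or a carboxylic acid in place of 4-fluorophenyl. They also leave open what a longer alkyl chain in place of thiophen-2-yl on the saturated ring carbon would do in this assay.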